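Urea terminus variation on a shared benzazepine-amide core

The source may hold more compounds than are shown below. What is called first, only, known or untested is meant among the compounds shown, and "the series" means these compounds.

Compound 3 `Cc1cc(C(=O)N2CCCCc3ccccc32)ccc1CNC(=O)NCC(=O)N1CCCCC1` is the member with the highest number among the three measured. In a functional assay on HEK293 cells for agonist activity at Vasopressin V2 receptor (Homo sapiens), read by a luciferase reporter and cAMP accumulation (on this read-out lower numbers stand for an effect already at smaller amounts and higher numbers for an effect only at larger amounts of compound), compound 3 gives 150 nM, compound 1 `Cc1cc(C(=O)N2CCCCc3ccccc32)ccc1CNC(=O)Nc1ccccc1F` gives 30 nM and compound 2 `COC(=O)CNC(=O)NCc1ccc(C(=O)N2CCCCc3ccccc32)cc1C` gives 37 nM; the two latter values lie within the scatter of each other, so no order between them is claimed.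

The next step goes from compound 3 to compound 4 `CCN(CC)C(=O)[C@@H]1CCCN1C(=O)NCc1ccc(C(=O)N2CCCCc3ccccc32)cc1C`: 2-(diethylcarbamoyl)pyrrolidin-1-yl in place of (((piperidin-1-yl)carbonyl)methyl)amino on a carbonyl carbon. The change leaves a urea with a secondary amide-type nitrogen and moves to one in which the ring nitrogen of the pyrrolidine carries the urea carbonyl, while an amide carbonyl is retained in the entering group.

Of the measured steps, a 4.1-fold higher number from compound 2 to compound 3 (0.61 log units; beyond the scatter) and a 5.0-fold higher number from compound 1 to compound 3 (0.70 log units; beyond the scatter) bear on it most: both concern what hangs from the urea terminus, and both were modest. Replacing a methoxy by a piperidinyl amide raised the number; compound 4 keeps an amide of similar kind but loses the donor and gains a ring at the urea nitrogen. Nothing measured here isolates that change, so the expectation in this assay is for no step beyond the scatter, with a slight lean toward a lower number: a 1.5-fold lower number from compound 3 to compound 4 (0.18 log units; within the scatter) is the estimated step. Compound 4 is therefore expected to give 100 nM, within the range 30 nM to 400 nM.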

Compound 4, half-maximal effective concentration: 350 nM
Beside the measured number, compound 4's estimate is 3.5-fold (0.54 log units) below it; the range from low to high includes it.
By their numbers in this assay, from the lowest: compounds 1 and 2 (each within the scatter of the next); then compound 3; then compound 4.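

In this assay, the step of a 2.3-fold higher number from compound 3 to compound 4 (0.37 log units; beyond the scatter) shows that the number at this position on a carbonyl carbon can rise beyond that of compound 3, so the piperidinyl amide did not mark the upper end of the series. Set against the two lowest members, 2-(diethylcarbamoyl)pyrrolidin-1-yl gives a 9.5-fold higher number from compound 2 to compound 4 (0.98 log units; beyond the scatter) and a 12-fold higher number from compound 1 to compound 4 (1.07 log units; beyond the scatter), the latter being the only large step so far, which makes the span at this position wider than the earlier compounds showed. The entering group differs from all three earlier groups at once in its ring, its 0 hydrogen-bond donors and its 1 defined stereocentre, and no measurement here accounts for the rise.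

From the compounds shown here alone, it remains open whether the higher number goes with the loss of the hydrogen on the urea nitrogen, with the ring, or with the diethylamide, as all of these change together in compound 4. A plain pyrrolidin-1-yl, a methyl on the urea nitrogen of compound 3, or the opposite configuration at the stereocentre would help to separate these contributions.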